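The source may report more compounds than this note shows. Statements on the series, on what has been measured and on what is new or still open speak of the compounds shown alone.

For the measured compounds named here, compound 2 `C#CC[C@@H]1C[C@H](n2cccc2C(=O)CC)C(=O)O1` is one of only two compounds measured in a functional assay on N2a cells (Mus musculus), with a stated time of 48 h, tested at 0.01 uM; a higher number here means a stronger effect of the compound at the concentration tested, a lower number a weaker effect. In this assay compound 2 gives 11.6%, and its number sits together with that of compound 1 `C#CC[C@H]1C[C@H](n2cccc2)C(=O)O1`, which gives 12.2%, the two within the scatter. Going by the values given here, compound 3 `C#CC[C@H]1C[C@H](n2cccc2C(=O)CC)C(=O)O1` awaits measurement. the two compounds have the same atoms and bonds and differ only in configuration as drawn: 1 of 2 stereo elements differ; a stereocentre at a saturated ring carbon is drawn R in compound 2 and S in compound 3 No step between measured compounds is available, so nothing shows how such a change acts here; the step from compound 2 to compound 3 is expected to stay within the scatter, with no clear direction, about a number 0.4 percentage points higher from compound 2 to compound 3 (within the scatter). Compound 3 is therefore estimated to give 12%, expected within a range from 2% to 25%.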

Compound 3, a percentage reported as activity, at one concentration (the size of the read-out at that concentration, not a potency): 4.63%
The estimate for compound 3 lay 7.4 percentage points above the measured number; measured number inside the range.
By their numbers in this assay, from the lowest: compounds 3, 2 and 1 (each within the scatter of the next).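

In this assay, for the compounds shown here, the change from R to S at a saturated ring carbon gives the first reading of this stereocentre, a number 7 percentage points lower from compound 2 to compound 3 (within the scatter) and so does not separate the two forms. This reading concerns configuration alone: the fact that compounds 2 and 3 differ only in the configuration as drawn. Propanoyl in place of hydrogen on an aromatic carbon gives a number 7.6 percentage points lower from compound 1 to compound 3 (within the scatter) and likewise separates nothing. Still open, going by these compounds, is whether an amine, a carboxylic acid or a longer chain in place of propanoyl would give a number beyond the scatter. Also open, on these data alone, is how either configuration would read with such a group.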